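The source may hold more compounds than are shown below. What is called first, only, known or untested is meant among the compounds shown, and "the series" means these compounds.

Compound 3 `O=C(N/N=C/c1ccc(O)cc1)Nc1cc2c(Nc3ccc(F)c(Cl)c3)ncnc2cc1O[C@H]1CCOC1` stands lowest of the three measured compounds in a functional assay on HepG2 cells (Homo sapiens) for cytotoxicity, read by MTT assay, with a stated time of 72 h (a lower number here means a stronger inhibitor, a higher number a weaker inhibitor), where compound 3 gives 70 nM. Compound 2 `O=C(N/N=C/c1ccc(O)c(Br)c1)Nc1cc2c(Nc3ccc(F)c(Cl)c3)ncnc2cc1O[C@H]1CCOC1` gives 660 nM in this assay, and compound 1 `COc1ccc(/C=N/NC(=O)Nc2cc3c(Nc4ccc(F)c(Cl)c4)ncnc3cc2O[C@H]2CCOC2)cc1` gives 28800 nM. The measured steps of a 44-fold lower number from compound 1 to compound 2 (1.64 log units; beyond the scatter), a 410-fold lower number from compound 1 to compound 3 (2.61 log units; beyond the scatter) and a 9.4-fold lower number from compound 2 to compound 3 (0.97 log units; beyond the scatter) all concern the ring attached to the carbon with a double bond to nitrogen. Compound 4 `COc1cc2ncnc(Nc3ccc(F)c(Cl)c3)c2cc1NC(=O)N/N=C/c1ccc(O)cc1` differs from compound 3 at a different place: methyl in place of oxolan-3-yl on an oxygen on an aromatic ring. Within the data shown here, none of the measured steps touches that oxygen, so nothing measured here says how large a change to expect; the shared core and the rest of the molecule are kept. In this assay compound 4 is expected to give about 150 nM, between 40 nM and 600 nM, an estimated step of a 2.1-fold higher number from compound 3 to compound 4 (0.33 log units; beyond the scatter) that may well stay within the scatter.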

Compound 4, half-maximal inhibitory concentration: 26300 nM
The estimate for compound 4 lay 180-fold (2.24 log units) below the measured number; measured number outside the range, above it.
By their numbers in this assay, from the lowest: compound 3; then compound 2; then compounds 4 and 1 (each within the scatter of the next).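

Changing the group on this oxygen from oxolan-3-yl to methyl in this assay gives a 380-fold higher number from compound 3 to compound 4 (2.57 log units; beyond the scatter), a large step. Among these compounds, the earlier compounds varied only the ring attached to the carbon with a double bond to nitrogen, so this is the first sign that the group on this oxygen also matters strongly. Nothing available explains why the step is so large. An ethyl group, a longer chain or a chain ending in an amine on this oxygen could show whether the ring itself counts. From the compounds shown here alone, the effect of the defined stereocentre also remains open.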